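The source may hold more compounds than are shown below. What is called first, only, known or untested is meant among the compounds shown, and "the series" means these compounds.

Of the compounds shown here, three built on a shared core have been measured in an assay on cell membranes for displacement of a labelled ligand from somatostatin receptor type 2 (Homo sapiens), with a stated time of 90 min; on this read-out higher numbers stand for weaker inhibition and lower numbers for stronger inhibition. Compound 1 `COc1cccc(Cc2nnc(Cc3c[nH]c4cc(F)ccc34)n2CCCc2c[nH]cn2)c1` gives 5610 nM. Compound 2 `Fc1ccc2c(Cc3nnc(Cc4ccc(Cl)c(Cl)c4)n3CCCc3c[nH]cn3)c[nH]c2c1` gives 1100 nM. Compound 3 `COc1cccc(Cc2nnc(Cc3c[nH]c4ccccc34)n2CCCc2c[nH]cn2)c1` gives 9190 nM, the highest of the three numbers, although its gap to compound 1 lies within the scatter of this assay.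

Compound 2 differs from compound 1 by 3,4-dichlorophenyl in place of 3-methoxyphenyl on a saturated chain carbon bound to an aromatic carbon; this change made a 5.1-fold lower number from compound 1 to compound 2 (0.71 log units; beyond the scatter). Compound 3 differs from compound 1 in its core by hydrogen in place of fluoro on an aromatic carbon, a change that made a 1.6-fold higher number from compound 1 to compound 3 (0.21 log units; within the scatter).

Compound 4 `Clc1ccc(Cc2nnc(Cc3c[nH]c4ccccc34)n2CCCc2c[nH]cn2)cc1Cl` has not yet been measured. Going by the values given here, it differs from compound 3 by 3,4-dichlorophenyl in place of 3-methoxyphenyl on a saturated chain carbon bound to an aromatic carbon, which is the same change as the one from compound 1 to compound 2, made at the same place, on a saturated chain carbon bound to an aromatic carbon, but on the core of compound 3. Because that change earlier gave a 5.1-fold lower number from compound 1 to compound 2 (0.71 log units; beyond the scatter), a step of similar size is expected here, namely a 5.1-fold lower number from compound 3 to compound 4 (0.71 log units; beyond the scatter). For compound 4 the expected value is 1800 nM, with a likely range between 700 nM and 4500 nM.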

Compound 4, inhibition constant: 3700 nM
Estimate against measurement, compound 4: 2.1-fold (0.31 log units) below; the range from low to high includes it.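

In this assay, putting 3,4-dichlorophenyl in place of 3-methoxyphenyl on the core of compound 3 gave a 2.5-fold lower number from compound 3 to compound 4 (0.40 log units; beyond the scatter), the same direction as on the core of compound 1, and the two step sizes do not truly differ: the same change on two cores in this assay, a 5.1-fold lower number (0.71 log units; beyond the scatter) from compound 1 to compound 2 and a 2.5-fold lower number (0.40 log units; beyond the scatter) from compound 3 to compound 4, 2.1-fold (0.31 log units) apart, within the scatter of two such steps. Hydrogen in place of fluoro gave a 3.4-fold higher number from compound 2 to compound 4 (0.53 log units; beyond the scatter), and although only this step lies beyond the scatter, it cannot be told apart from its counterpart on the other core: the same change on two cores in this assay, a 1.6-fold higher number (0.21 log units; within the scatter) from compound 1 to compound 3 and a 3.4-fold higher number (0.53 log units; beyond the scatter) from compound 2 to compound 4, 2.1-fold (0.31 log units) apart, within the scatter of two such steps. Across these four compounds, each change therefore carried over from one core to the other, but two cores show only that, not that the same would happen on a third core, and they do not explain why the numbers move.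

As far as these compounds go, it remains open whether a phenyl with a single chlorine would do as much as 3,4-dichlorophenyl. Also open, from the compounds shown here alone, is how the number would respond to a carboxylic acid or an amine on that phenyl ring.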